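Benzoate ester with a nitrophenyl group: an expected value

A few compounds are considered here, and "the series" means these few. Any claim that something is new, unique, unknown or untested is made for them only; others in the source may bear on it.

Two measured compounds frame this step. Compound 1 `CC(=O)OC/C(=C\c1ccccc1[N+](=O)[O-])C(=O)c1ccccc1` gives 18000 nM in a functional assay on WiDr cells (Homo sapiens) for inhibition, read by sulforhodamine B assay, with a stated time of 48 h; on this read-out lower numbers stand for stronger inhibition of growth and higher numbers for weaker inhibition of growth. Compound 2 `O=C(OC/C(=C\c1ccc(Cl)cc1Cl)C(=O)c1ccccc1)c1ccccc1` gives 17000 nM in this assay, a number that sits alongside that of compound 1 within the scatter. Compound 3 `O=C(OC/C(=C\c1ccccc1[N+](=O)[O-])C(=O)c1ccccc1)c1ccccc1` differs from compound 2 by one change: 2-nitrophenyl in place of 2,4-dichlorophenyl on a double-bonded chain carbon bound to a double-bonded chain carbon. Both measured compounds carry the same core and end near the same value, so the change is expected to move the number little, none beyond the scatter, giving an estimated step of no change at the digits printed from compound 2 to compound 3 (within the scatter). Compound 3 is therefore estimated at 17000 nM, with a range from 8000 nM to 36000 nM.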

Compound 3, concentration for 50% growth inhibition: 18000 nM
Estimate against measurement, compound 3: 1.1-fold (0.02 log units) below; the range from low to high includes it.
By their numbers in this assay, from the lowest: compounds 2, 1 and 3 (each within the scatter of the next).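

In this assay, 2-nitrophenyl in place of 2,4-dichlorophenyl on a double-bonded chain carbon bound to a double-bonded chain carbon gives a 1.1-fold higher number from compound 2 to compound 3 (0.02 log units; within the scatter), so with the benzoate ester held constant, this position accepts either group without a readable shift. Phenyl in place of methyl on a carbonyl carbon gives no change at the digits printed from compound 1 to compound 3 (within the scatter), the first direct reading of a change at that place. No available evidence accounts for these two flat steps.

Going by these compounds, it remains open whether an amine or a carboxylic acid on the aromatic ring, or a longer chain on the carbonyl carbon, would move the number beyond the scatter.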